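Chloro to methoxy: compound 3 to compound 4

The compounds below may be only part of what the source reports. "The series", "measured", "known", "first", "only" and "open" are said of these compounds alone.

In a functional assay on HeLa cells (Homo sapiens) for antiproliferative activity, read by MTT assay, with a stated time of 72 h (on this read-out higher numbers stand for weaker inhibition and lower numbers for stronger inhibition), compound 1 (`COc1cc(C(=O)c2sc3ccccc3c2-c2ccc(F)cc2)cc(OC)c1OC`) gives 3000 nM, compound 2 (`COc1ccc(OC)c(-c2c(C(=O)c3cc(OC)c(OC)c(OC)c3)sc3ccccc23)c1`) gives 10000 nM and compound 3 (`COc1cc(C(=O)c2sc3ccccc3c2Nc2ccc(Cl)cc2)cc(OC)c1OC`) gives 3700 nM. Two steps fix where compound 3 stands on these numbers: a 1.2-fold higher number from compound 1 to compound 3 (0.09 log units; within the scatter), and a 2.7-fold lower number from compound 2 to compound 3 (0.43 log units; beyond the scatter). It is therefore level with compound 1 and clear of compound 2.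

Compound 4 (`COc1ccc(Nc2c(C(=O)c3cc(OC)c(OC)c(OC)c3)sc3ccccc23)cc1`) follows from compound 3 by methoxy in place of chloro on an aromatic carbon, para to a large group.

Going by the values given here, no measured step makes this exchange. The nearest evidence exchanges the whole group on the same carbon of the core. The largest such step, a 3.3-fold higher number from compound 1 to compound 2 (0.52 log units; beyond the scatter), is only modest, although it replaces far more than the change at hand. Compound 2 does carry methoxy groups, but three compounds do not settle a direction, so no step beyond the scatter is expected. The expected step is a 1.2-fold lower number from compound 3 to compound 4 (0.09 log units; within the scatter). For compound 4 the estimated value is 3000 nM, with an expected range of 500 nM to 10000 nM.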

Compound 4, half-maximal inhibitory concentration: 7700 nM
Compound 4: middle estimate off by 2.6-fold (0.41 log units), on the low side; the measured number falls inside the stated range.
By their numbers in this assay, from the lowest: compounds 1 and 3 (each within the scatter of the next); then compounds 4 and 2 (each within the scatter of the next).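

In this assay, going by these compounds alone, the first single-substituent exchange gives a step beyond the scatter (a 2.1-fold higher number from compound 3 to compound 4 (0.32 log units; beyond the scatter)), so the group para to a large group matters on its own, whereas the earlier steps replaced the whole group on that carbon of the core. With (4-methoxyphenyl)amino on that carbon, compound 4 stays within the scatter of the 2,5-dimethoxyphenyl compound (a 1.3-fold lower number from compound 2 to compound 4 (0.11 log units; within the scatter)) but lies clear of the 4-fluorophenyl compound (a 2.6-fold higher number from compound 1 to compound 4 (0.41 log units; beyond the scatter)), so among these four compounds the two carrying methoxy on the side ring give the higher numbers, and none goes against this. Nothing measured here explains the step.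

An amine or a carboxylic acid in place of the methoxy would show whether the higher number is particular to methoxy. A 4-methoxyphenyl group joined directly to the core would test whether the step holds without the amino link.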